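The source may hold more compounds than are shown below. What is called first, only, known or untested is meant among the compounds shown, and "the series" means these compounds.

- Compound 1 `Nc1nc(Nc2ccc(S(N)(=O)=O)cc2)sc1C(=O)c1ccccc1[N+](=O)[O-]`: 500 nM
- Compound 2 `Nc1nc(Nc2ccc(S(N)(=O)=O)cc2)sc1C(=O)c1cccc(F)c1`: 980 nM
- Compound 3 `Nc1nc(Nc2ccc(S(N)(=O)=O)cc2)sc1C(=O)c1ccc(S(N)(=O)=O)cc1`: 8700 nM

In a functional assay on T47D cells (Homo sapiens) for cytotoxicity, read by fluorescence and resazurin assay, with a stated time of 72 h (a higher number here means a weaker inhibitor, a lower number a stronger inhibitor), compound 2, at 980 nM, lies within the scatter of compound 1 and well under compound 3 at 8700 nM. The next compound, compound 4 `Nc1cccc(C(=O)c2sc(Nc3ccc(S(N)(=O)=O)cc3)nc2N)c1`, has amino in place of fluoro on an aromatic carbon. Among the compounds with values here, no measured step makes this exact exchange. The nearest is a 2.0-fold higher number from compound 1 to compound 2 (0.29 log units; within the scatter), which is a change of the group on the carbonyl carbon and stays within the scatter. Compound 3 at 8700 nM shows that a wider gap can occur among these compounds, so the range is kept broad. The expected change is a 1.2-fold lower number from compound 2 to compound 4 (0.09 log units; within the scatter), which means no expected step beyond the scatter. For compound 4 the estimated value is 800 nM, with an expected range of 250 nM to 2800 nM.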

Compound 4, half-maximal inhibitory concentration: 5800 nM
For compound 4 the middle estimate is 7.3-fold (0.86 log units) below the measured one; the whole stated range lies below it.
By their numbers in this assay, from the lowest: compounds 1 and 2 (each within the scatter of the next); then compounds 4 and 3 (each within the scatter of the next).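

In this assay, this aromatic carbon proves sensitive to the exchange of fluoro for amino, with a 5.9-fold higher number from compound 2 to compound 4 (0.77 log units; beyond the scatter). The 3-aminophenyl group also separates clearly from 2-nitrophenyl on the carbonyl carbon, with a 12-fold higher number from compound 1 to compound 4 (1.06 log units; beyond the scatter), whereas 3-fluorophenyl had stayed within the scatter of 2-nitrophenyl. No measurement offered here explains the weaker result with amino. On these data alone, whether a hydroxyl, methoxy or acetamide group on the same carbon would behave like amino or like fluoro remains open. So does whether amino would give the same step on another carbon of this ring.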